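Swapping dimethylamino for methoxy in compound 3

The source may hold more compounds than are shown below. What is called first, only, known or untested is meant among the compounds shown, and "the series" means these compounds.

Among the compounds with values here, in a functional assay on NB1 cells (Homo sapiens) for antiproliferative activity, with a stated time of 72 h (on this read-out higher numbers stand for weaker inhibition and lower numbers for stronger inhibition), compound 2 `CN(C)c1ccc(C(=O)N(CCC(=O)NCc2ccccc2)Cc2ccc(C(=O)NO)cc2)cc1` gives 1720 nM, the lower of the two numbers so far, while compound 1 `O=C(CCN(Cc1ccc(C(=O)NO)cc1)C(=O)c1ccccc1)NCc1ccccc1` gives 6660 nM. Compound 3 `COc1ccc(C(=O)N(CCC(=O)NCc2ccccc2)Cc2ccc(C(=O)NO)cc2)cc1` carries methoxy in place of dimethylamino on an aromatic carbon, para to a large group: methoxy in place of dimethylamino on an aromatic carbon. Within the data shown here, one measured step bears on this place, a 3.9-fold lower number from compound 1 to compound 2 (0.59 log units; beyond the scatter), where dimethylamino replaced hydrogen. That step was modest and involved no methoxy, so only a small move toward a higher number in this assay is expected. The expected step is a 1.7-fold higher number from compound 2 to compound 3 (0.24 log units; within the scatter). For compound 3 the estimated value is 3000 nM, within a range of 1300 nM to 7000 nM.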

Compound 3, half-maximal inhibitory concentration: 2520 nM
Estimate against measurement, compound 3: 1.2-fold (0.08 log units) above, and the stated range covers the measured number.
By their numbers in this assay, from the lowest: compounds 2 and 3 (each within the scatter of the next); then compound 1.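

With a 1.5-fold higher number from compound 2 to compound 3 (0.17 log units; within the scatter), methoxy and dimethylamino cannot be told apart at this aromatic carbon in this assay. Methoxy in place of hydrogen gives a 2.6-fold lower number from compound 1 to compound 3 (0.42 log units; beyond the scatter), so a lower number than with hydrogen here now goes with two different groups, not with dimethylamino alone. Nothing on hand explains why these two groups give such similar numbers. Going by these compounds, whether an amine, a carboxylic acid or a longer chain such as ethoxy at this carbon would also give a lower number than hydrogen stays open. So does whether methoxy and dimethylamino would match at another carbon of this ring.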